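Amide side-chain swap on a chloropurine oral analgesic

The source may report more compounds than this note shows. Statements on the series, on what has been measured and on what is new or still open speak of the compounds shown alone.

Of the compounds shown here, three of one chloropurine-derived series have been measured in a functional assay on the whole organism (Tail, strain ICR) with Mus musculus as the target, in the tail flick test, with a stated time of 30 min, at a dose of 25 umol/kg by the oral route; on this read-out lower numbers stand for a weaker effect and higher numbers for a stronger effect at the one dose given. Compound 1, `CC(C)[C@H](NC(=O)CN(c1nc(Cl)nc2[nH]cnc12)C1CC1)C(=O)OCc1ccccc1`, gives 33.4% in this assay. Compound 3, `O=C(OCc1ccccc1)[C@@H]1CCCN1C(=O)CN(c1nc(Cl)nc2[nH]cnc12)C1CC1`, gives 33.2%, a value that lies within the scatter of compound 1 and therefore cannot be set apart from it. Compound 2, `O=C(CN(c1ncnc2c1ncn2C1CCCCO1)C1CC1)NCC(=O)OCc1ccccc1`, gives 55.7%, which stands beyond the scatter above compound 1; compound 2 also carries a different core, so its higher number cannot be tied to any single change. Compound 4, `O=C(CN(c1nc(Cl)nc2[nH]cnc12)C1CC1)N[C@@H](CC(=O)OCc1ccccc1)C(=O)OCc1ccccc1`, has not yet been measured in this assay. It differs from compound 1 in one place: (benzyloxycarbonyl)methyl in place of isopropyl on a saturated chain carbon bound to an amide-type nitrogen and a carbonyl carbon. Going by the values given here, no pair of measured compounds differing in one place is available, so the size of such a step is unknown. Compound 4 is expected to stay close to compound 1, with the step of a number 1.6 percentage points higher from compound 1 to compound 4 (within the scatter) not beyond the scatter, because compound 3 with 33.2% shows that a change of this part of the molecule left the number essentially where it was. For compound 4 an activity of 35% is estimated, expected to fall between 15% and 58%.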

Compound 4, a percentage reported as activity, at one dose (the size of the read-out at that dose, not a potency): 34.7%
Compound 4: middle estimate off by 0.3 percentage points, on the high side, within the range that was stated.
By their numbers in this assay, from the lowest: compounds 3, 1 and 4 (each within the scatter of the next); then compound 2.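

In this assay, going by these compounds alone, (benzyloxycarbonyl)methyl in place of isopropyl gives a number 1.3 percentage points higher from compound 1 to compound 4 (within the scatter), the first step that can be read at this position, on a saturated chain carbon bound to an amide-type nitrogen and a carbonyl carbon. The entering group brings 11 heavy atoms against 3, along with a six-membered aromatic ring of carbon only and 2 hydrogen-bond acceptors, yet the step stays within the scatter, so at this one dose the read-out does not respond to this large change. Nothing measured here accounts for that result.

On these data alone, whether a free carboxylic acid or an amine on this chain would leave the number in place remains open. The higher number of compound 2, which has a different core, still cannot be tied to any single change.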